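The compounds below may be only part of what the source reports. "The series", "measured", "known", "first", "only" and "open" are said of these compounds alone.

Compound 1 `O=C(COc1ccc2cc(/C=C3/SC(=O)NC3=O)ccc2c1)Nc1cc(Cl)cc(C(F)(F)F)c1` carries a 3-chloro-5-(trifluoromethyl)phenyl on the amide-type nitrogen. In an assay on isolated protein for inhibition of histone deacetylase 8 (Homo sapiens), with a stated time of 1 h (a higher number here means a weaker inhibitor, a lower number a stronger inhibitor), compound 1 returns only a limit, > 50000 nM. Compound 2 `O=C(COc1ccc2cc(/C=C3/SC(=O)NC3=O)ccc2c1)Nc1ccccn1` bears pyridin-2-yl at that nitrogen instead, and in this assay compound 2 likewise returns only a limit, > 50000 nM. The step that the two limits leave unreadable from compound 1 to compound 2 is therefore unreadable, and the limit of > 50000 nM in this assay, at which 2 of the 2 values shown sit, is where the measured series sits. Compound 3 `O=C(COc1ccc2cc(/C=C3/SC(=O)NC3=O)ccc2c1)Nc1ccccc1` differs from compound 1 by phenyl in place of 3-chloro-5-(trifluoromethyl)phenyl on an amide-type nitrogen. No readable measured step bears on this change, so in this assay compound 3 is expected to stay at the limit, an expected step of a number no higher from compound 1 to compound 3 (the limit leaves the size open). Compound 3 is estimated at 50000 nM, range 15000 nM to 200000 nM.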

Compound 3, half-maximal inhibitory concentration: 4500 nM
Compound 3: the middle estimate sits 11-fold (1.05 log units) above what was measured, outside the stated range (below it).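

The amide-type nitrogen is now shown to be a position where the substituent decides whether a value can be read in this assay: phenyl gives an at least 11-fold lower number from compound 1 to compound 3 (1.04 log units; beyond the scatter), and it gives an at least 11-fold lower number from compound 2 to compound 3 (1.04 log units; beyond the scatter). As far as these compounds go, each step starts from a limit, so its full size stays open. The other two substituents at this nitrogen remain at that limit: the limit of > 50000 nM in this assay, at which 2 of the 3 values shown sit.

Still open, from the compounds shown here alone, is whether the chlorine, the trifluoromethyl or both separate compound 1 from compound 3. Also open, going by these compounds, is how a methoxy or a carboxylic acid on the phenyl of compound 3 would read.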